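Series notes: fluoro to trifluoromethyl, second instance

A few compounds are considered here, and "the series" means these few. Any claim that something is new, unique, unknown or untested is made for them only; others in the source may bear on it.

Measured so far in a functional assay on the whole organism (strain Swiss) with Mus musculus as the target, in the maximal electroshock model, with a stated time of 0.5 h, at a dose of 300 mg/kg by the intraperitoneal route; a lower number here means a weaker effect, a higher number a stronger effect of the compound at the dose given:
compound 1 `CCC(C(=O)N1CCN(c2cccc(F)c2)CC1)N1C(=O)CCC1=O` gives 100%
compound 3 `CC(C(=O)N1CCN(c2ccc(F)cc2)CC1)N1C(=O)CCC1=O` gives 50%
compound 2 `CC(C(=O)N1CCN(c2ccc(C(F)(F)F)cc2)CC1)N1C(=O)CCC1=O` gives 25%

Compound 1 stands highest of the three in this assay, and its nearest neighbour is compound 3. How the core of compound 1 differs from the core of compound 3 is not broken down here. Compound 3 and compound 2 differ in one place, (trifluoromethyl in place of fluoro on an aromatic carbon), and this gives a number 25 percentage points lower from compound 3 to compound 2 (beyond the scatter).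

Compound 4 `CCC(C(=O)N1CCN(c2cccc(C(F)(F)F)c2)CC1)N1C(=O)CCC1=O` is not yet measured. It differs from compound 1 by trifluoromethyl in place of fluoro on an aromatic carbon. The place is not the same word for word: in compound 4 the group sits meta to a large group, in compound 2 para to a large group, so this is the same kind of change rather than the same change. Compound 4 is expected to show a number 25 percentage points lower from compound 1 to compound 4 (beyond the scatter), a step of roughly the size of a number 25 percentage points lower from compound 3 to compound 2 (beyond the scatter), resting on that single earlier instance. Compound 4 is therefore estimated at 75%, expected between 50% and 100%.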

Compound 4, a percentage reported as activity, at one dose (the size of the read-out at that dose, not a potency): 50%
Compound 4: middle estimate off by 25 percentage points, on the high side; the measured number falls inside the stated range.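

In this assay, trifluoromethyl in place of fluoro on an aromatic carbon again goes with a lower number, a number 50 percentage points lower from compound 1 to compound 4 (beyond the scatter), so the direction is shared by both cores, but the size of the step does not carry over: the same change on two cores in this assay, a number 25 percentage points lower (beyond the scatter) from compound 3 to compound 2 and a number 50 percentage points lower (beyond the scatter) from compound 1 to compound 4, 25 percentage points apart, beyond the scatter of two such steps

With two instances, the change can be carried from one core to the other as a direction only, and a step read on one core is no reliable measure of the step on the other. The two pairs differ both in the core and in the place, with the group meta to a large group in compound 4 and para to a large group in compound 2, and these data do not show which of the two goes with the gap.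

Left open is what the same change gives at one fixed place on both cores. Also open, from the compounds shown here alone, is whether the direction extends to other groups on that aromatic carbon, such as a nitrile or an amine.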